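A few compounds are considered here, and "the series" means these few. Any claim that something is new, unique, unknown or untested is made for them only; others in the source may bear on it.

Compounds measured in a functional assay on HEK293 cells for agonist activity at D(4) dopamine receptor (Homo sapiens), read by FLIPR (on this read-out lower numbers stand for an effect already at smaller amounts and higher numbers for an effect only at larger amounts of compound), so far:
Compound 1 `O=C(CN1CCC(c2cccc[n+]2[O-])CC1)Nc1ccc(F)cc1F` gives 103 nM in this assay.
Compound 2 `O=C(CN1CCC(c2cccc[n+]2[O-])CC1)NC1CCCCC1` gives 294 nM.
Compound 3 `O=C(CN1CCC(c2cccc[n+]2[O-])CC1)Nc1cccc(Cl)c1` gives 62 nM.

Compound 3 shows the lowest of the three numbers, although one of the two gaps (a 1.7-fold lower number from compound 1 to compound 3 (0.22 log units; within the scatter)) stays within the scatter; only the other gap (a 4.7-fold lower number from compound 2 to compound 3 (0.68 log units; beyond the scatter)) is beyond it. Compound 4 `Cc1cccc(C)c1NC(=O)CN1CCC(c2cccc[n+]2[O-])CC1` differs from compound 3 as follows: 2,6-dimethylphenyl in place of 3-chlorophenyl on an amide-type nitrogen. The step that bears on this is the aryl-to-aryl exchange a 1.7-fold lower number from compound 1 to compound 3 (0.22 log units; within the scatter), which stayed within the scatter; the larger step of a 4.7-fold lower number from compound 2 to compound 3 (0.68 log units; beyond the scatter) involved a non-aromatic group and is less relevant. The expected step is therefore small, a 1.5-fold higher number from compound 3 to compound 4 (0.19 log units; within the scatter), with no direction beyond the scatter. Compound 4 is estimated at 95 nM, range 40 nM to 250 nM.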

Compound 4, half-maximal effective concentration: 346 nM
Compound 4: middle estimate off by 3.6-fold (0.56 log units), on the low side, and the stated range ends below it.
By their numbers in this assay, from the lowest: compounds 3 and 1 (each within the scatter of the next); then compounds 2 and 4 (each within the scatter of the next).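

In this assay an exchange of one substituted phenyl for another on the amide-type nitrogen is not necessarily a small change: a 5.6-fold higher number from compound 3 to compound 4 (0.75 log units; beyond the scatter) and a 3.4-fold higher number from compound 1 to compound 4 (0.53 log units; beyond the scatter) both lie beyond the scatter. An aromatic ring at this place does not by itself keep the number low, as a 1.2-fold higher number from compound 2 to compound 4 (0.07 log units; within the scatter) stays within the scatter.

The compounds shown offer no measurement that explains the rise with 2,6-dimethylphenyl. As far as these compounds go, whether a plain phenyl or a benzyl group would fall with compound 3 or with compound 4 remains open.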